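The source may report more compounds than this note shows. Statements on the series, on what has been measured and on what is new or still open speak of the compounds shown alone.

In a functional assay on MCF7 cells (Homo sapiens) for antiproliferative activity, read by MTT assay, with a stated time of 24 h, tested at 12.5 uM (on this read-out higher numbers stand for a weaker effect at the one concentration tested and lower numbers for a stronger effect), compound 1 `OC(CCn1nc2c(Br)c(Br)c(Br)c(Br)c2n1)c1ccc(F)cc1` gives 116%, compound 2 `COc1cccc(C(O)CCn2nc3c(Br)c(Br)c(Br)c(Br)c3n2)c1` gives 121%, and compound 3 `C[C@@H](O)CCn1nc2c(Br)c(Br)c(Br)c(Br)c2n1` gives 109%. Compound 3 thus holds the lowest of the three numbers, though its gap to compound 1 lies within the scatter; only compound 2 stands beyond it. Going by the values given here, the one step between measured compounds, a number 5 percentage points higher from compound 1 to compound 2 (within the scatter), exchanges one aryl group for another and leaves the stereocentre untouched. Compound 4 `C[C@H](O)CCn1nc2c(Br)c(Br)c(Br)c(Br)c2n1` differs from compound 3 as follows: the two compounds have the same atoms and bonds and differ only in configuration as drawn: 1 of 1 stereo elements differ; a stereocentre at a saturated chain carbon is drawn R in compound 3 and S in compound 4. Among the compounds with values here, no measured step alters configuration alone, so the data give no direct guide to the size or direction of this change; the only comparison available, the aryl exchange, stayed within the scatter, and the whole series sits in a narrow band. Compound 4 is therefore expected to move by a number 1 percentage points higher from compound 3 to compound 4 (within the scatter), nothing beyond the scatter. Compound 4 is estimated in this assay at 110%, with a range from 98% to 124%.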

Compound 4, a percentage reported as activity, at one concentration (the size of the read-out at that concentration, not a potency): 112%
Estimate against measurement, compound 4: 2 percentage points below; low and high end bracket the measured number.
By their numbers in this assay, from the lowest: compounds 3, 4, 1 and 2 (each within the scatter of the next, the first and the last beyond it).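

In this assay, going by these compounds alone, the stereocentre at the saturated chain carbon gives the first direct reading of configuration alone, and the change from R to S is a number 3 percentage points higher from compound 3 to compound 4 (within the scatter). Within the data shown here, the only earlier step exchanged one aryl group for another and left this centre untouched, so the earlier compounds could say nothing about it. At the one concentration tested, configuration at this carbon does not separate the pair, and this reading is a clean one: the fact that compounds 3 and 4 differ only in the configuration as drawn.

The compounds shown leave open whether configuration matters once an aryl group sits on this carbon, as the stereocentre in compound 1 and compound 2 carries no drawn configuration. They also leave open whether an amine in place of the hydroxyl, or a longer chain, would move the number beyond the scatter.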